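Swapping the aryl group on a sulfonyl: predicting compound 3

This account rests on a few compounds, and the source may have more. Where it says the series, first, only, none or still open, it means among the compounds named here.

Within the data shown here, compound 2 `Cc1ccc2ncc(S(=O)(=O)c3ccc(C)c(Cl)c3)c(N3CCC(C)CC3)c2c1` gives 91% in an assay on isolated protein for displacement of a labelled ligand from metabotropic glutamate receptor 5 (Homo sapiens), with a stated time of 60 min, tested at 1 uM (on this read-out lower numbers stand for less inhibition and higher numbers for more inhibition at the one concentration tested (going by the name of the read-out)), the higher of the two numbers measured so far; compound 1 `COc1ccc(S(=O)(=O)c2cnc3ccc(C)cc3c2N2CCC(C)CC2)cc1` gives 62%. Among the measured compounds shown here, the only measured step, a number 29 percentage points higher from compound 1 to compound 2 (beyond the scatter), shows that changing the aryl group on the sulfonyl sulfur can shift the read-out substantially. Compound 3 `Cc1ccc2ncc(S(=O)(=O)c3ccc(C#N)cc3)c(N3CCC(C)CC3)c2c1` differs from compound 2 by 4-cyanophenyl in place of 3-chloro-4-methylphenyl on a sulfonyl sulfur. For the measured compounds named here, no measured step covers this exact exchange, so the direction is uncertain; a moderate fall is expected, as a number 26 percentage points lower from compound 2 to compound 3 (beyond the scatter). Compound 3 is therefore estimated at 65%, with a range from 35% to 90%.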

Compound 3, a percentage reported as inhibition, at one concentration (the size of the read-out at that concentration, not a potency): 55%
For compound 3 the middle estimate is 10 percentage points above the measured one; the range from low to high includes it.
By their numbers in this assay, from the lowest: compounds 3 and 1 (each within the scatter of the next); then compound 2.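

In this assay, the change to 4-cyanophenyl on the sulfonyl sulfur takes the number down sharply (a number 36 percentage points lower from compound 2 to compound 3 (beyond the scatter)), so a second group now stands well under 3-chloro-4-methylphenyl. Cyano in place of methoxy on an aromatic carbon leaves compounds 1 and 3 within the scatter (a number 7 percentage points lower from compound 1 to compound 3 (within the scatter)), so the two groups cannot be told apart here. No measurement shown explains these differences.

The compounds shown do not separate the contribution of the chlorine from that of the methyl in 3-chloro-4-methylphenyl. Going by these compounds, how an amine or a carboxylic acid on the phenyl ring would read remains open.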